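The source may hold more compounds than are shown below. What is called first, only, known or untested is meant among the compounds shown, and "the series" means these compounds.

Within the data shown here, in a functional assay on MCF7 cells (Homo sapiens) for cytotoxicity, read by MTT assay, with a stated time of 72 h (on this read-out lower numbers stand for stronger inhibition and higher numbers for weaker inhibition), the series offers one number so far. Compound 1 (`N[C@H]1CC[C@H](Nc2c(C(=O)NCc3ccc(F)cc3)nc(Br)c3cccnc23)CC1`), which carries a cyclic diamine-derived substituent on the shared core, gives 2000 nM. Compound 2 (`CNc1c(C(=O)NCc2ccc(F)cc2)nc(Br)c2cccnc12`), with a methylamino group on that core, stands as "not determined" (no result reported), so it has no position on the numerical scale and cannot serve as a measured starting point. The next compound to be tested is compound 3 (`COC(=O)CNc1c(C(=O)NCc2ccc(F)cc2)nc(Br)c2cccnc12`). The structural change is methoxycarbonyl in place of hydrogen on a saturated chain carbon bound to a nitrogen on an aromatic ring, which turns methyl into (methoxycarbonyl)methyl. With no number for compound 2, the size of this step in this assay cannot be read from the data, and any expectation has to lean on the single measured anchor, compound 1 at 2000 nM. A moderate shift toward weaker inhibition than that anchor is expected, though with wide uncertainty. For compound 3 the expected value is 7000 nM, with an estimated range from 2000 nM to 25000 nM.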

Compound 3, half-maximal inhibitory concentration: > 10000 nM
Compound 3 ended at the assay's limit; the forecaster's own chance of this, stated with the estimate: 30%; middle value at least 1.4-fold (0.15 log units) from the limit.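

In this assay compound 3 reads as a limit of the assay and not as a number: the limit of > 10000 nM in this assay, at which 1 of the 3 values shown sits. Among these compounds, on a nitrogen on an aromatic ring, (methoxycarbonyl)methyl in place of 4-aminocyclohexyl gives an at least 5.0-fold higher number from compound 1 to compound 3 (0.69 log units; beyond the scatter), the first comparison, and it shows that the read-out responds to what this nitrogen carries, although the size of the step is bounded from one side only. The step from methyl to (methoxycarbonyl)methyl, which is the change at the saturated chain carbon itself, cannot be read, as compound 2 has no number.

The compounds shown leave open whether the difference follows the amine of the 4-aminocyclohexyl group or its ring, a question that a plain cyclohexyl on the same nitrogen would separate. They also leave open whether a carboxylic acid in place of the methyl ester, or a longer chain ending in an amine, would bring the number back towards that of compound 1 (2000 nM).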